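The source may report more compounds than this note shows. Statements on the series, on what has been measured and on what is new or still open speak of the compounds shown alone.

Compound 1 `NNC(=O)CCc1ccncc1-c1ccc2ccccc2c1` was examined in a functional assay on KB cells (Homo sapiens) for inhibition, read by sulforhodamine B assay, with a stated time of 72 h; on this read-out lower numbers stand for stronger inhibition of growth and higher numbers for weaker inhibition of growth. In this assay compound 1 reaches only the limit of > 10000 nM, not a number. Compound 2 `Cn1ccc2cc(-c3cnccc3/C=C/C(=O)O)ccc21`, a related compound, likewise stops at the limit of > 10000 nM in this assay. Where compound 1 stands is thus fixed only by the limit of > 10000 nM in this assay, at which 2 of the 2 values shown sit, and no finer placing is possible. Compound 3 `O=C(/C=C/c1ccncc1-c1ccc2ccccc2c1)NC1CC1` differs from compound 1 by 2-(cyclopropylcarbamoyl)ethenyl in place of 2-(aminocarbamoyl)ethyl on an aromatic carbon. Going by the values given here, no step between two measured compounds is available, so the size of this change cannot be read from the data; both measured values sit at the limit of > 10000 nM in this assay, at which 2 of the 2 values shown sit, so only a step well beyond the scatter toward stronger inhibition would bring compound 3 into the measurable range, while a smaller step would leave it at the limit. Compound 3 is expected at 8000 nM, within 1500 nM to 30000 nM, an expected step of an at least 1.2-fold lower number from compound 1 to compound 3 (0.09 log units; that floor lies within the scatter).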

Compound 3, concentration for 50% growth inhibition: 6050 nM
For compound 3 the middle estimate is 1.3-fold (0.12 log units) above the measured one; measured number inside the range.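

Compound 3 gives the first number rather than a limit in this assay among the compounds shown, so growth inhibition can be measured with a change at this aromatic carbon, opposite the ring nitrogen. From the compounds shown here alone, replacing 2-(aminocarbamoyl)ethyl with 2-(cyclopropylcarbamoyl)ethenyl gives an at least 1.6-fold lower number from compound 1 to compound 3 (0.21 log units; that floor lies within the scatter) and this is only a floor, so the full size of the step stays unknown and what is printed does not place it beyond the scatter. The limit of compound 1 still bounds this comparison: the limit of > 10000 nM in this assay, at which 2 of the 3 values shown sit.

The change alters the chain and the group on the amide nitrogen together, so the compounds shown do not separate the double bond from the cyclopropyl ring. Going by these compounds, it also remains open how a simple methyl amide or an amine on the same ethenyl chain would behave.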